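Swapping naphthalen-1-yl for 4-cyanobenzyl on the shared core

A few compounds are considered here, and "the series" means these few. Any claim that something is new, unique, unknown or untested is made for them only; others in the source may bear on it.

Compound 3 `c1coc(CNCCCNc2ccnc3cc(-c4cccc5ccccc45)ccc23)c1` gives the lowest of the three numbers in an ADME assay on HepG2 cells (Homo sapiens) for cytotoxicity, read by luminescence, CellTiter-Glo and ATP content, with a stated time of 72 h (a lower number here means that less compound is needed, a higher number that more compound is needed for the effect), at 5600 nM. Compound 2 `Fc1ccc(Cc2ccc3c(NCCCNCc4ccco4)ccnc3c2)c(Cl)c1` stands nearest, at 5730 nM, and the two lie within the scatter of each other (a 1.0-fold lower number from compound 2 to compound 3 (0.01 log units; within the scatter)). Compound 1 `CC(C)Cc1ccc2c(NCCCNCc3ccco3)ccnc2c1` stands furthest, at 16000 nM, with a 2.9-fold lower number from compound 1 to compound 3 (0.46 log units; beyond the scatter). The next compound, compound 4 `N#Cc1ccc(Cc2ccc3c(NCCCNCc4ccco4)ccnc3c2)cc1`, changes one place: 4-cyanobenzyl in place of naphthalen-1-yl on an aromatic carbon. The step that bears most on this is the one where 2-chloro-4-fluorobenzyl gave way to naphthalen-1-yl, a 1.0-fold lower number from compound 2 to compound 3 (0.01 log units; within the scatter), which stayed within the scatter, and compound 4 returns a benzyl-type group to that position. Compound 4 is therefore expected to show a step of a 1.3-fold higher number from compound 3 to compound 4 (0.10 log units; within the scatter). The value of compound 4 is estimated at 7000 nM, between 2500 nM and 20000 nM.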

Compound 4, half-maximal effective concentration: 7910 nM
Compound 4: middle estimate off by 1.1-fold (0.05 log units), on the low side; measured number inside the range.
By their numbers in this assay, from the lowest: compounds 3, 2 and 4 (each within the scatter of the next); then compound 1.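

In this assay, 4-cyanobenzyl with its nitrile stays within the scatter of both naphthalen-1-yl (a 1.4-fold higher number from compound 3 to compound 4 (0.15 log units; within the scatter)) and 2-chloro-4-fluorobenzyl (a 1.4-fold higher number from compound 2 to compound 4 (0.14 log units; within the scatter)), so these three groups cannot be told apart at this position. Only the isobutyl of compound 1 stands apart, and the step to the nitrile-bearing compound is modest (a 2.0-fold lower number from compound 1 to compound 4 (0.31 log units; beyond the scatter)). Nothing available explains why these groups read alike. Going by these compounds, whether an amine or a carboxylic acid at this position would stay with these three compounds remains open.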